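Swapping the chlorines for methyls on the piperazine aryl

A few compounds are considered here, and "the series" means these few. Any claim that something is new, unique, unknown or untested is made for them only; others in the source may bear on it.

Of the compounds shown here, two have been tested in a functional assay on HL-60 cells (Homo sapiens) for inhibition, read by MTT assay, with a stated time of 72 h; on this read-out higher numbers stand for weaker inhibition and lower numbers for stronger inhibition. Compound 1 `COc1ccc(-c2nc(C)oc2C(=O)N2CCN(c3cccc(Cl)c3)CC2)cc1` was recorded as "not active" (no number reported), so it gives no number to compare against. For the measured compounds named here, compound 2 `Cc1nc(-c2ccccc2)c(C(=O)N2CCN(c3ccc(Cl)c(Cl)c3)CC2)o1` is therefore the only compound with a measured value: in this assay compound 2 gives 124 nM. Going by the values given here, it is the sole reference point; no step between measured compounds can be stated.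

Compound 3 `Cc1ccc(N2CCN(C(=O)c3oc(C)nc3-c3ccccc3)CC2)c(C)c1` differs from compound 2 in one place: 2,4-dimethylphenyl in place of 3,4-dichlorophenyl on an amine nitrogen in a ring. Among the compounds with values here, the group that leaves and the group that enters both carry an aromatic ring with two substituents, but no pair of measured compounds in this small set shows how such a swap plays out.

With nothing to guide the direction, the estimate for compound 3 leans toward somewhat weaker inhibition than compound 2 showed, and the expected step of a 3.2-fold higher number from compound 2 to compound 3 (0.51 log units; beyond the scatter) is of moderate size, although a change within the scatter cannot be ruled out. In this assay compound 3 is expected to give about 400 nM, with a plausible range from 120 nM to 2000 nM.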

Compound 3, half-maximal inhibitory concentration: 101 nM
Compound 3: the middle estimate sits 4.0-fold (0.60 log units) above what was measured; measured number below the stated range.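

In this assay, placing 2,4-dimethylphenyl where 3,4-dichlorophenyl stood on the amine nitrogen in the ring gives a 1.2-fold lower number from compound 2 to compound 3 (0.09 log units; within the scatter), so the two compounds cannot be told apart. For the compounds shown here, this is the first readable step, and it shows that, at least for this pair, inhibition in this cell assay does not depend on chlorine atoms on this aryl ring: two methyl groups serve as well, even though the substituents also sit at different ring positions. Nothing available explains why the two aryl groups perform alike, and no measurement of any property of these groups accompanies the result.

The step changes both the kind of substituent and where the substituents sit, so the compounds shown do not reveal whether either change alone would matter, or whether the two effects simply cancel out. From the compounds shown here alone, it also remains open how this position would respond to a plain phenyl ring, a pyridine ring, or an aryl group bearing an amine or a carboxylic acid.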